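The compounds below may be only part of what the source reports. "The series", "measured", "known", "first", "only" and "open" are said of these compounds alone.

Of the compounds shown here, three have been measured in a functional assay on RAW264.7 cells (Mus musculus) for inhibition, read by Griess assay, with a stated time of 24 h; on this read-out higher numbers stand for weaker inhibition and lower numbers for stronger inhibition. Compound 1 `C=CCc1ccc(OCC=C(C)C)c(-c2ccc(OC)c(CC=C)c2)c1` reads > 100000 nM, which is a limit of the assay and not a number. Compound 2 `C=CCc1ccc(OC(=O)NCc2ccccc2)c(-c2ccc(OC)c(CC=C)c2)c1` reads > 100000 nM, which is likewise only a limit. The set is therefore marked by the limit of > 100000 nM in this assay, at which 2 of the 3 values shown sit. Among the measured compounds shown here, compound 3 `C=CCc1ccc(O)c(-c2cc(CCC)on2)c1` gives 61000 nM, the only true number among the three.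

Compound 4 `C=CCc1ccc(O)c(-c2cc(CO)on2)c1` differs from compound 3 by a single change, (hydroxy in place of ethyl on a saturated chain carbon bound to an aromatic carbon). The same difference, cut one bond further out, reads propyl to hydroxymethyl. For the measured compounds named here, the only measured step, a step that the two limits leave unreadable from compound 1 to compound 2, involves a different change and offers no size to carry over. Going by the values given here, with no measured step to size this change, the expectation rests on compound 3 at 61000 nM. A modest move towards weaker inhibition is expected, given as an estimated 1.4-fold higher number from compound 3 to compound 4 (0.14 log units; within the scatter). For compound 4 the expected value is 85000 nM, with an estimated range of 30000 nM to 250000 nM.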

Compound 4, half-maximal inhibitory concentration: 36000 nM
For compound 4 the middle estimate is 2.4-fold (0.37 log units) above the measured one, within the range that was stated.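

In this assay, hydroxy in place of ethyl on a saturated chain carbon bound to an aromatic carbon, which also reads as propyl to hydroxymethyl, gives a 1.7-fold lower number from compound 3 to compound 4 (0.23 log units; within the scatter), so at this position the two groups cannot be told apart beyond the usual scatter. Among the compounds shown here, this is the first step in the set with a readable size, since the step between compound 1 and compound 2 cannot be read. Compound 4 gives a true number, as compound 3 does, while the set remains marked by a limit of the assay: the limit of > 100000 nM in this assay, at which 2 of the 4 values shown sit.

The compounds shown leave open how an amine, a carboxylic acid or a longer chain at this place would read in this assay. They also leave open whether propyl to hydroxymethyl would give a similar step on the core of compound 1.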